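The source may hold more compounds than are shown below. What is called first, only, known or untested is meant among the compounds shown, and "the series" means these compounds.

Compounds measured in a functional assay on BGC-823 cells (Homo sapiens) for antiproliferative activity, read by MTT assay, with a stated time of 48 h; a lower number here means a stronger inhibitor, a higher number a weaker inhibitor:
compound 1 `Cc1ccccc1CSc1nnc(-c2ccc3c(c2)OCCO3)o1` gives 22600 nM
compound 2 `Fc1ccccc1CSc1nnc(-c2ccc3c(c2)OCCO3)o1` gives 29000 nM
compound 3 `c1ccc(CSc2nnc(-c3ccc4c(c3)OCCO4)o2)cc1` gives 33600 nM

Compound 3 carries the highest of the three numbers, yet its gaps to compound 2 and compound 1 stay within the scatter, so the three compounds cannot be placed in order. Compound 4 `Brc1ccc(CSc2nnc(-c3ccc4c(c3)OCCO4)o2)cc1` differs from compound 3 by bromo in place of hydrogen on an aromatic carbon. Within the data shown here, the steps that bear on it are those that altered a substituent on the benzyl ring: a 1.5-fold higher number from compound 1 to compound 3 (0.17 log units; within the scatter) and a 1.2-fold higher number from compound 2 to compound 3 (0.06 log units; within the scatter), both within the scatter. Nothing measured here separates a substituted benzyl ring from a bare one beyond the scatter, so compound 4 is expected to give a number close to that of compound 3, with a 1.3-fold lower number from compound 3 to compound 4 (0.13 log units; within the scatter). The estimate for compound 4 in this assay is 25000 nM, with a range from 10000 nM to 60000 nM.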

Compound 4, half-maximal inhibitory concentration: 22300 nM
Estimate against measurement, compound 4: 1.1-fold (0.05 log units) above; low and high end bracket the measured number.
By their numbers in this assay, from the lowest: compounds 4, 1, 2 and 3 (each within the scatter of the next).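

Bromo, para to a large group, is the first substituent here placed away from the 2-position of the benzyl ring, and in this assay it gives a 1.5-fold lower number from compound 3 to compound 4 (0.18 log units; within the scatter). Changing the ring's substitution as well leaves the reading unmoved, with a 1.3-fold lower number from compound 2 to compound 4 (0.11 log units; within the scatter) and a 1.0-fold lower number from compound 1 to compound 4 (0.01 log units; within the scatter), so neither the 4-bromophenyl, 2-fluorophenyl nor 2-methylphenyl group stands apart from the bare phenyl beyond the scatter. No measurement shown accounts for this flatness. As far as these compounds go, whether an amine, a carboxylic acid or a longer chain at this place would shift the number beyond the scatter remains open.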